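From Nitro to Chloro on a Weak Compound

This account rests on a few compounds, and the source may have more. Where it says the series, first, only, none or still open, it means among the compounds named here.

Compound 1 `COc1ccc(-c2snnc2-c2cc(OC)c(OC)c(OC)c2)cc1O` gives 1.5 nM in a functional assay on HL-60 cells (Homo sapiens) for antiproliferative activity; on this read-out lower numbers stand for stronger inhibition and higher numbers for weaker inhibition. For compound 2 `COc1cc(-c2nnsc2-c2ccc([N+](=O)[O-])cc2)cc(OC)c1OC`, this assay gives > 1000 nM, which is a limit and not a number. Compound 2 therefore has no exact position on this scale.

Compound 3 `COc1cc(-c2nnsc2-c2ccc(Cl)cc2)cc(OC)c1OC` has not yet been measured. It differs from compound 2 in one place, with chloro in place of nitro on an aromatic carbon, para to a large group: chloro in place of nitro on an aromatic carbon.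

Going by the values given here, no measured step between closely matched compounds is available as a guide, so any forecast here is rough. A modest move towards stronger inhibition is expected, though the change may not rise beyond the scatter. Compound 3 is expected to remain much weaker than compound 1, which stands at 1.5 nM. The expected change is an at least 1.6-fold lower number from compound 2 to compound 3 (0.22 log units; that floor lies within the scatter). For compound 3, the estimated value is 600 nM, within an expected range of 60 nM to 5000 nM.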

Compound 3, half-maximal inhibitory concentration: 23.6 nM
The estimate for compound 3 lay 25-fold (1.41 log units) above the measured number; the measured number lies below the stated range.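

On this position of the ring, para to a large group, a single swap is enough to change the picture: chloro in place of nitro gives an at least 42-fold lower number from compound 2 to compound 3 (1.62 log units; beyond the scatter) in this assay. The step is large and lies beyond the scatter, so the group at this one place has a strong hold on the read-out, which compound 1 and compound 2 alone could not show. Its true size remains unknown, as compound 2 supplies a limit and not a number: the limit of > 1000 nM in this assay, at which 1 of the 3 values shown sits.

The compounds shown cannot say whether chloro itself brings the gain or whether losing nitro is what matters. On these data alone, how an amine, a methyl or a carboxylic acid at the same place would compare also remains open.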